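Adding a 2-carboxyethyl arm to a bridged lactone core

A few compounds are considered here, and "the series" means these few. Any claim that something is new, unique, unknown or untested is made for them only; others in the source may bear on it.

Compound 1, `CC1(C)[C@@H]2CC3=NCC(=O)O[C@@]3(C)[C@H]1C2`, is the starting point of this step. Within the data shown here, in a functional assay on MCF7 cells (Homo sapiens) for antiproliferative activity, read by sulforhodamine B assay, with a stated time of 48 h (on this read-out higher numbers stand for weaker inhibition and lower numbers for stronger inhibition), compound 1 gives 22000 nM, the only actual number among the values shown. Compound 2, `CC1(C)[C@H]2CC3=NCC(=O)O[C@]3(C)[C@@H]1C2`, is its mirror image, and in this assay compound 2 gives only a limit, > 300000 nM. Among the measured compounds shown here, the one measured step, an at least 13-fold higher number from compound 1 to compound 2 (1.13 log units; beyond the scatter), is therefore large, and it rests on the fact that compounds 1 and 2 differ only in the configuration as drawn together with the limit of > 300000 nM in this assay, at which 1 of the 2 values shown sits.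

Compound 3, `CC1(C)[C@@H]2CC3=N[C@@H](CCC(=O)O)C(=O)O[C@@]3(C)[C@H]1C2`, keeps the configuration of compound 1 and changes one place: 2-carboxyethyl in place of hydrogen on a saturated ring carbon. For the measured compounds named here, no measured step here concerns adding a group; the only step compares mirror images, so it says nothing about a 2-carboxyethyl arm. With no guide on this kind of change, compound 3 is expected to stay close to compound 1, and the expected step is a 1.4-fold higher number from compound 1 to compound 3 (0.13 log units; within the scatter), which is not beyond the scatter. The estimate for compound 3 in this assay is 30000 nM, expected to lie between 8000 nM and 120000 nM.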

Compound 3, half-maximal inhibitory concentration: 38000 nM
Estimate against measurement, compound 3: 1.3-fold (0.10 log units) below, within the range that was stated.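

Putting 2-carboxyethyl in place of hydrogen on this saturated ring carbon, next to the ring nitrogen, gives in this assay a step that is no larger than repeated measurements of one compound can differ: a 1.7-fold higher number from compound 1 to compound 3 (0.24 log units; within the scatter). Among these compounds, the earlier compounds showed only what inverting every stereocentre does, whereas this is the first measured change at a single place on the core, and it shows that this position can carry an arm of 5 heavy atoms, ending in a group with a hydrogen-bond donor, without a change that stands out from the scatter. The information available gives no explanation for this outcome, since what it records concerns only the mirror-image pair and the assay limit, not this arm.

Going by these compounds, what remains open is whether any part of the arm matters: a plain propyl chain, a shorter carboxymethyl arm, a longer 3-carboxypropyl chain, or an amine at the chain end could each tell the acid from the chain. The compounds shown also leave open how the opposite configuration at this ring carbon, with the same arm, would behave.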